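The compounds below may be only part of what the source reports. "The series", "measured", "known", "first", "only" and "open" are said of these compounds alone.

In a functional assay for inhibition, with Homo sapiens as the target (on this read-out higher numbers stand for weaker binding and lower numbers for tighter binding), compound 1 `O=C(O)CC/C=C\CC1COC(c2ccco2)OC1c1cccnc1` gives 1260 nM, and compound 2 `O=C(O)CC/C=C\CC1COC(c2ccc3ccccc3c2)OC1c1cccnc1` gives 1780 nM. These two values lie within the usual scatter of each other, so compound 2 stands level with compound 1. Compound 3 `O=C(O)CC/C=C\CC1COC(c2cccc3ccccc23)OC1c1cccnc1` has not yet been measured. It differs from compound 2 in one place: naphthalen-1-yl in place of naphthalen-2-yl on a saturated ring carbon. Within the data shown here, no measured step tests this exchange directly. Among the measured compounds shown here, the only step that bears on it is the exchange of furan-2-yl for naphthalen-2-yl on the same carbon, a 1.4-fold higher number from compound 1 to compound 2 (0.15 log units; within the scatter). For the measured compounds named here, with only that small step as a guide, no change beyond the scatter is expected in this assay, and the expected step is a 1.2-fold lower number from compound 2 to compound 3 (0.07 log units; within the scatter). Compound 3 is estimated at 1500 nM, with an expected range of 600 nM to 3800 nM.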

Compound 3, dissociation constant: 631 nM
Compound 3: middle estimate off by 2.4-fold (0.38 log units), on the high side, within the range that was stated.
By their numbers in this assay, from the lowest: compounds 3, 1 and 2 (each within the scatter of the next, the first and the last beyond it).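

In this assay, among these compounds, the exchange of naphthalen-2-yl for naphthalen-1-yl on this saturated ring carbon, between two ring oxygen atoms, gives a 2.8-fold lower number from compound 2 to compound 3 (0.45 log units; beyond the scatter) and is the first step at this position to pass beyond the scatter, though modestly, so the way the same carbon atoms are joined to this carbon can be read in this assay. The exchange of furan-2-yl for naphthalen-1-yl gives a 2.0-fold lower number from compound 1 to compound 3 (0.30 log units; within the scatter) and stays within the scatter, so these two groups stand level here, while the two naphthalene-derived groups do not. Nothing available explains the difference between naphthalen-1-yl and naphthalen-2-yl.

The compounds shown leave open how a phenyl or quinolin-4-yl group would read on this carbon. They also leave open whether the gain from naphthalen-1-yl would persist with a longer chain in place of the 5-carboxypent-2-en-1-yl group.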